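A few compounds are considered here, and "the series" means these few. Any claim that something is new, unique, unknown or untested is made for them only; others in the source may bear on it.

Compound 1 (`O=C(O)CCCCC(CCSC(=O)c1ccccc1)SC(=O)c1ccccc1`) is reported in a functional assay on NCI-H460 cells (Homo sapiens) for inhibition, read by MTT assay, with a stated time of 24 h, tested at 10 ug/mL (a higher number here means more inhibition of growth at the concentration tested, a lower number less inhibition of growth), as "not active" (no number reported) without a single number. Compound 2 (`O=C(CCCCC(S)CCS)NO`) gives 17.7% in this assay and compound 3 (`O=C(CCCCC(CCSC(=O)c1ccccc1)SC(=O)c1ccccc1)Nc1ccccc1`) gives 11.4% there, two numbers that lie within the usual scatter of each other. On these results, compound 3 cannot be separated from compound 2.

Compound 4 (`O=C(CCCCC(CCSC(=O)c1ccccc1)SC(=O)c1ccccc1)Nc1ccccc1Cl`) is compound 3 with a single change. That change is chloro in place of hydrogen on an aromatic carbon and it puts chloro in place of hydrogen on an aromatic carbon, ortho to a large group, so that phenyl becomes 2-chlorophenyl. For the measured compounds named here, no pair of measured compounds shows what such a swap does, so nothing here supports a large move in either direction. The expected size of a number 1.6 percentage points higher from compound 3 to compound 4 (within the scatter) in this assay is small, within the scatter, with no firm direction. The estimate therefore starts from compound 3 at 11.4% and stays close to it. Compound 4 is expected to give 13% with an estimated range from 3% to 28% when it is measured.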

Compound 4, percent growth inhibition at one concentration: 12.1%
Beside the measured number, compound 4's estimate is 0.9 percentage points above it; low and high end bracket the measured number.
By their numbers in this assay, from the lowest: compounds 3, 4 and 2 (each within the scatter of the next).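

For the compounds shown here, the earlier compounds offered no pair differing in one place, so this is the only direct reading of a change on this ring. Chloro in place of hydrogen on an aromatic carbon, ortho to a large group, gives a number 0.7 percentage points higher from compound 3 to compound 4 (within the scatter) in this assay, so at this single concentration the phenyl and 2-chlorophenyl compounds cannot be told apart. No other measurement shown bears on this result.

Going by these compounds, whether a methoxy or an amino group on that same carbon would move the number beyond the usual scatter remains open. On these data alone, it is also open whether chloro on another carbon of the ring, or a longer chain between the core and the amide carbonyl, would change growth inhibition.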